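Sulfonamide series: quinoxalinyl in place of pyridinyl

A few compounds are considered here, and "the series" means these few. Any claim that something is new, unique, unknown or untested is made for them only; others in the source may bear on it.

Measured so far:
compound 1 `NC1=NN(c2ccccc2)C(=O)/C1=C/Nc1ccc(S(=O)(=O)Nc2ccccn2)cc1` — 91.8%
compound 2 `Cc1cc(C)nc(NS(=O)(=O)c2ccc(N/C=C3/C(=N)N(c4ccccc4)N=C3N)cc2)n1` — 88.4%

In a functional assay on HepG2 cells (Homo sapiens) for positive allosteric modulation, tested at 40 uM (on this read-out lower numbers stand for a weaker effect and higher numbers for a stronger effect at the one concentration tested), compound 1 gives 91.8%. Compound 2 gives 88.4% in this assay, and the two numbers lie within the scatter of each other, so compound 1 cannot be set apart from compound 2 on these data; both simply sit near the top of the scale at the concentration tested.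

Compound 3 `NC1=NN(c2ccccc2)C(=O)/C1=C/Nc1ccc(S(=O)(=O)Nc2cnc3ccccc3n2)cc1` has not yet been measured. It differs from compound 1 in one place: quinoxalin-2-yl in place of pyridin-2-yl on a sulfonamide nitrogen. Among the measured compounds shown here, no measured pair shows the effect of such a change, so the expectation rests on the level of compound 1 alone. With both measured compounds near the ceiling, little room remains upward, and the step from compound 1 to compound 3 is expected to be a number 6.8 percentage points lower from compound 1 to compound 3 (within the scatter), a change not beyond the scatter. Compound 3 is estimated at 85%, with a range of 62% to 98%.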

Compound 3, a percentage reported as activity, at one concentration (the size of the read-out at that concentration, not a potency): 88.5%
Beside the measured number, compound 3's estimate is 3.5 percentage points below it; measured number inside the range.
By their numbers in this assay, from the lowest: compounds 2, 3 and 1 (each within the scatter of the next).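

On the sulfonamide nitrogen, quinoxalin-2-yl in place of pyridin-2-yl gives a number 3.3 percentage points lower from compound 1 to compound 3 (within the scatter) in this assay. The group at this position can therefore go from 6 to 10 heavy atoms, with one more six-membered aromatic ring and a second hydrogen-bond acceptor, without a change that can be told from the scatter at the one concentration tested. No data on hand bear on the reason for this.

The read-out comes from a single concentration; whether compound 1 and compound 3 differ in the strength of their effect at other concentrations remains unresolved. Also open, from the compounds shown here alone, is whether this nitrogen accepts a substituent without an aromatic ring, such as cyclohexyl or a short chain ending in a carboxylic acid, while the read-out stays at this level.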